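A few compounds are considered here, and "the series" means these few. Any claim that something is new, unique, unknown or untested is made for them only; others in the source may bear on it.

Measured in a functional assay on HL-60 cells (Homo sapiens) for inhibition, read by resazurin assay, with a stated time of 72 h; a lower number here means a stronger inhibitor, a higher number a weaker inhibitor:
- compound 1 `CCSc1ccc(C2C(Oc3ccccc3)C(=O)N2c2cc(OC)c(OC)c(OC)c2)cc1`: 508 nM
- compound 2 `COc1cc(N2C(=O)C(Oc3ccccc3)C2c2ccc(SC)cc2)cc(OC)c1OC`: 388 nM
- compound 3 `CCOc1ccc(C2C(O)C(=O)N2c2cc(OC)c(OC)c(OC)c2)cc1`: 11 nM

Compound 3 has the lowest number of the three, beyond the scatter from both others. Compound 4 `CCOc1ccc(C2C(Oc3ccccc3)C(=O)N2c2cc(OC)c(OC)c(OC)c2)cc1` is derived from it by one change, (phenyl in place of hydrogen on an oxygen on a saturated carbon), which reads as hydroxy to phenoxy: phenyl in place of hydrogen on an oxygen on a saturated carbon.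

Going by the values given here, no measured step covers this change directly. Among the compounds with values here, the only measured step, a 1.3-fold lower number from compound 1 to compound 2 (0.12 log units; within the scatter), lies within the scatter and concerns the chain on sulfur, so it says nothing about the hydroxy to phenoxy change. It does allow the two phenoxy compounds to be read together as a guide. Both differ from compound 4 at another part of the structure, with compound 1 at 508 nM and compound 2 at 388 nM.

A large upward move in this assay, towards weaker inhibition and beyond the scatter, is therefore expected: a 36-fold higher number from compound 3 to compound 4 (1.56 log units; beyond the scatter). The estimate for compound 4 is 400 nM, with an expected range of 150 nM to 1000 nM.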

Compound 4, half-maximal inhibitory concentration: 494 nM
Compound 4: the middle estimate sits 1.2-fold (0.09 log units) below what was measured; low and high end bracket the measured number.
By their numbers in this assay, from the lowest: compound 3; then compounds 2, 4 and 1 (each within the scatter of the next).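

In this assay the hydroxy to phenoxy change now has a direct reading on a single core (a 45-fold higher number from compound 3 to compound 4 (1.65 log units; beyond the scatter)), and it is a large step towards weaker inhibition. With phenoxy in place, ethoxy on the aromatic carbon does not separate from methylsulfanyl (a 1.3-fold higher number from compound 2 to compound 4 (0.10 log units; within the scatter)) or from ethylsulfanyl (a 1.0-fold lower number from compound 1 to compound 4 (0.01 log units; within the scatter)), so these three compounds read as one level. No supporting data bear on why the step from hydroxy to phenoxy is so large.

Open, as far as these compounds go, is whether the loss follows the phenyl itself or any group on this oxygen, which a methyl or a benzyl there, or an amine in place of the hydroxy, would address. Also open, from the compounds shown here alone, is whether the same step holds with methylsulfanyl or ethylsulfanyl in place of ethoxy.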